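Hydrogen in place of phenyl, at a limit

The source may hold more compounds than are shown below. What is called first, only, known or untested is meant among the compounds shown, and "the series" means these compounds.

In a toxicity assay on NIH3T3 cells (Mus musculus) for cytotoxicity, read by resazurin assay (on this read-out lower numbers stand for an effect already at smaller amounts and higher numbers for an effect only at larger amounts of compound), compound 3 (`COC(=O)c1ccc(NCc2cncn2Cc2ccc(-c3ccccc3)cc2)cc1-c1ccccc1`) gives > 1000 nM, which is a limit and not a number. Compound 1 (`COC(=O)c1ccc(NCc2cncn2Cc2ccccc2)cc1-c1ccccc1`) gives > 1000 nM, which is also a limit. Going by the values given here, compound 2 (`COC(=O)c1ccc(NCc2cncn2Cc2ccccc2N)cc1-c1ccccc1`) gives 25000 nM, the only actual number. Compound 3 therefore has no exact place on the scale, and the series is dominated by the limit of > 1000 nM in this assay, at which 2 of the 3 values shown sit.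

Compound 4 (`COC(=O)c1ccc(NCc2cncn2Cc2ccc(-c3ccccc3)cc2)cc1`) departs from compound 3 in one place: hydrogen in place of phenyl on an aromatic carbon, ortho to a methoxycarbonyl group and meta to a large group (hydrogen in place of phenyl on an aromatic carbon). The closest measured precedent is a step that the two limits leave unreadable from compound 1 to compound 3, the same kind of exchange in the opposite sense and at a different place in the molecule. The other two measured steps are no more informative: a step that the limit leaves unreadable from compound 1 to compound 2, and a step that the limit leaves unreadable from compound 2 to compound 3.

Among the compounds with values here, no measured step therefore supports a size or a direction for this change, and the only numerical anchor is compound 2 at 25000 nM. The expected change is a step that the limit leaves unreadable from compound 3 to compound 4, an estimate that carries little support from the measured steps. Compound 4 is estimated at 15000 nM, with an expected range from 2500 nM to 60000 nM.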

Compound 4, half-maximal effective concentration: > 10000 nM
Compound 4 gave a limit, no number (the forecaster's own chance of this, stated with the estimate: 55%); the middle value lies beyond the limit too.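

Compound 3 and compound 4 both stand at limits and not at numbers, so the step between them cannot be read in size or in direction. The compounds shown leave open where either compound truly lies on the scale, and whether hydrogen in place of phenyl changes the cytotoxic effect at all.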